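Swapping a dichloropyridine for a chloropyridine on the amide

The source may report more compounds than this note shows. Statements on the series, on what has been measured and on what is new or still open speak of the compounds shown alone.

Compound 2 `O=C(Nc1cccc(-c2nc3ccccc3s2)c1)c1ccc(Cl)nc1Cl` stands at the ceiling of an ADME assay on HEK293 cells (Homo sapiens) for inhibition, with a stated time of 72 h (on this read-out higher numbers stand for an effect only at larger amounts of compound and lower numbers for an effect already at smaller amounts), where compound 2 gives > 25000 nM, which is a limit rather than a number. Compound 1 `CC(Cl)C(=O)Nc1cccc(-c2nc3ccccc3s2)c1` likewise gives > 25000 nM in this assay, again only a limit. Hence a step that the two limits leave unreadable from compound 1 to compound 2 cannot be read, both values sitting at the limit of > 25000 nM in this assay, at which 2 of the 2 values shown sit. Compound 3 `O=C(Nc1cccc(-c2nc3ccccc3s2)c1)c1ccncc1Cl` differs from compound 2 by 3-chloropyridin-4-yl in place of 2,6-dichloropyridin-3-yl on a carbonyl carbon. Among the compounds with values here, no measured step bears readably on this change. Compound 3 is therefore expected to remain at that ceiling as well, with an estimated 25000 nM (range 8000 nM to 100000 nM). The expected a number no higher from compound 2 to compound 3 (the limit leaves the size open) is no step beyond the scatter.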

Compound 3, half-maximal effective concentration: > 25000 nM
Compound 3 gave a limit, no number; the forecaster's own chance of this, stated with the estimate: 80%; the middle value lies on the limit itself.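

No step can be read among compound 1, compound 2 and compound 3, since all three give only a limit: the limit of > 25000 nM in this assay, at which 3 of the 3 values shown sit.

The compounds shown leave open whether any group on the carbonyl carbon would give a readable number in this assay.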